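From hydroxy to ethoxy on compound 3

The source may report more compounds than this note shows. Statements on the series, on what has been measured and on what is new or still open speak of the compounds shown alone.

Measured so far in a functional assay on MDA-MB-231 cells (Homo sapiens) for cytotoxicity, read by sulforhodamine B assay, with a stated time of 3 days; a higher number here means that more compound is needed for the effect, a lower number that less compound is needed:
Compound 1 `COC(=O)c1c(C)coc1-c1ccc2c(c1OC)CCCC2(C)C` gives 61 uM
Compound 2 `Cc1coc(-c2ccc3c(c2O)CCCC3(C)C)c1C(=O)O` gives 24.7 uM
Compound 3 `Cc1coc(-c2ccc3c(c2O)CCCC3(C)C)c1CO` gives 39.5 uM

Within the scatter of both compound 1 and compound 2 stands compound 3 at 39.5 uM. Compound 4 `CCOc1c(-c2occ(C)c2CO)ccc2c1CCCC2(C)C` comes from compound 3 by a single change, (ethyl in place of hydrogen on an oxygen on an aromatic ring), so that hydroxy becomes ethoxy, with ethyl in place of hydrogen on an oxygen on an aromatic ring.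

Within the data shown here, no measured step isolates a change at that oxygen. Among the measured compounds shown here, the one available step, a 1.6-fold higher number from compound 2 to compound 3 (0.20 log units; within the scatter), is a different change, hydroxymethyl in place of carboxy on an aromatic carbon, and it bears on the new one only by showing how little this series has moved so far. Compound 1 also lacks the hydrogen on that oxygen and gives 61 uM, but it differs from compound 3 in a second place as well, so it offers only a weak hint toward a higher number.

In this assay no change beyond the scatter is therefore expected. The expected step is a 1.1-fold higher number from compound 3 to compound 4 (0.06 log units; within the scatter). Compound 4 is estimated at 45 uM, with an expected range from 20 uM to 100 uM.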

Compound 4, concentration for half-maximal effect: 39.8 uM
Beside the measured number, compound 4's estimate is 1.1-fold (0.05 log units) above it, and the stated range covers the measured number.
By their numbers in this assay, from the lowest: compounds 2, 3, 4 and 1 (each within the scatter of the next, the first and the last beyond it).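

In this assay, among these compounds, ethyl in place of hydrogen on an oxygen on an aromatic ring gives a 1.0-fold higher number from compound 3 to compound 4 (0.00 log units; within the scatter), which is the first reading from a pair differing only at this oxygen. For this pair, then, the hydrogen on that oxygen is not needed to hold the number where it stands, and the ethyl group is accommodated with no step beyond the scatter. No available evidence bears on why this change leaves the number as it is.

From the compounds shown here alone, whether a longer chain, a benzyl group or a chain carrying an amine on this oxygen would give a step beyond the scatter remains open. Also open, going by these compounds, is whether hydroxy to ethoxy would read the same on compound 2, which carries carboxy where compound 3 carries hydroxymethyl.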